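From Fluoro to Chloro on an Aromatic Carbon

The source may report more compounds than this note shows. Statements on the series, on what has been measured and on what is new or still open speak of the compounds shown alone.

Measured in a physicochemical assay for lipophilicity, read by HPLC, in phosphate buffer, measured as octanol-water partition, at pH 7.4, tested at 100 uM; on this read-out lower numbers stand for lower lipophilicity and higher numbers for higher lipophilicity:
- Compound 1 (`CCOc1cc(C)c(-c2cccc(CNc3ccc(OCC(=O)O)c(F)c3)c2)c(C)c1`) gives 3.04
- Compound 2 (`O=C(O)COc1ccc(NCc2cccc(-c3ccccc3)c2)cc1F`) gives 2.25
- Compound 3 (`O=C(O)COc1ccc(NCc2cccc(-c3ccccc3F)c2)cc1F`) gives 2.36

Among these three numbers, compound 3 lies within the usual scatter of compound 2, while compound 1 stands clearly higher. Compound 4 (`O=C(O)COc1ccc(NCc2cccc(-c3ccccc3Cl)c2)cc1F`) has not yet been measured. It differs from compound 3 by a single swap, 2-fluorophenyl to 2-chlorophenyl, which puts chloro in place of fluoro on an aromatic carbon. The swap sits ortho to a large group.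

Among the compounds with values here, only one measured step bears on this change. When fluoro took the place of hydrogen on an aromatic carbon, the result was a number 0.11 log units higher from compound 2 to compound 3 (within the scatter) and so a small step. Within the data shown here, no measured compound carries chloro, which makes this a loose guide. Taking it as the only hint, a modest upward step in this assay is expected, near the edge of the usual scatter. The estimated step is a number 0.29 log units higher from compound 3 to compound 4 (within the scatter) and remains an expectation until it is measured. For compound 4 the estimated value is 2.65 (expected range 2.4 to 2.95).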

Compound 4, distribution coefficient: 2.71
Compound 4: middle estimate off by 0.06 log units, on the low side, within the range that was stated.
By their numbers in this assay, from the lowest: compounds 2 and 3 (each within the scatter of the next); then compound 4; then compound 1.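

At this place on the aromatic carbon, ortho to a large group, the choice of halogen makes a readable difference in this assay: chloro in place of fluoro gives a number 0.35 log units higher from compound 3 to compound 4 (beyond the scatter) and so separates the two halogens. Set against the plain phenyl of compound 2, chloro gives a number 0.46 log units higher from compound 2 to compound 4 (beyond the scatter) while fluoro gives only a number 0.11 log units higher from compound 2 to compound 3 (within the scatter), so among these compounds chloro is the one group at this place that moves the number clearly away from hydrogen. None of the measurements shown gives a reason for this difference between chloro and fluoro.

As far as these compounds go, whether the upward trend from fluoro to chloro would carry on to bromo, or whether methyl, methoxy or an amine at the same place would raise or lower the number, stays open. Compound 1 differs from these compounds in more than one place, so it cannot show how much any single group on its ring contributes to its number.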